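A few compounds are considered here, and "the series" means these few. Any claim that something is new, unique, unknown or untested is made for them only; others in the source may bear on it.

The compounds measured so far in a functional assay on RKE cells for antagonist activity at Vasoactive intestinal polypeptide receptor 1 (Rattus norvegicus), read by HTRF and cAMP accumulation, with stated times of 10 min and 30 min; a higher number here means a weaker inhibitor, a lower number a stronger inhibitor:

compound 1, `Cc1ccccc1-c1cc(C(C)(C)C)cc(C(C)C)c1CO`, > 50000 nM.
compound 2, `COc1ccccc1-c1cc(C(C)(C)C)cc(C(C)C)c1CO`, 820 nM.
compound 3, `Cc1cccc(CCC(=O)Nc2sc3c(c2C#N)CCCC3)c1`, 750 nM.

For compound 1 the value is a limit of the assay, not a number (the limit of > 50000 nM in this assay, at which 1 of the 3 values shown sits). Compound 2 carries the change (methoxy in place of methyl on an aromatic carbon), and in this assay this gives an at least 60-fold lower number from compound 1 to compound 2 (1.78 log units; beyond the scatter), a step whose true size is open because one end is a limit.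

Compound 3 is built on a different core; the difference between the two cores is not broken down here. In this assay compound 3 and compound 2 sit within the scatter of each other.

Compound 4, `COc1cccc(CCC(=O)Nc2sc3c(c2C#N)CCCC3)c1`, is not yet measured. It differs from compound 3 by methoxy in place of methyl on an aromatic carbon. This is the same kind of change as that from compound 1 to compound 2, but not the same: there the methoxy stands ortho to a large group, here meta to a large group.

For compound 4 a lower number is expected, a 1.9-fold lower number from compound 3 to compound 4 (0.27 log units; within the scatter), because compound 3 gives 750 nM and the earlier step was an at least 60-fold lower number from compound 1 to compound 2 (1.78 log units; beyond the scatter). The estimate for compound 4 is 400 nM, between 100 nM and 1500 nM.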

Compound 4, half-maximal inhibitory concentration: 610 nM
Estimate against measurement, compound 4: 1.5-fold (0.18 log units) below; measured number inside the range.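

In this assay, methoxy in place of methyl on an aromatic carbon gives a 1.2-fold lower number from compound 3 to compound 4 (0.09 log units; within the scatter), so the large step seen on the core of compound 1 does not reappear on the core of compound 3, and the two steps differ: the same change on two cores in this assay, an at least 60-fold lower number (1.78 log units; beyond the scatter) from compound 1 to compound 2 and a 1.2-fold lower number (0.09 log units; within the scatter) from compound 3 to compound 4, at least 49-fold (1.69 log units) apart, beyond the scatter of two such steps The earlier step has no fixed size, as compound 1 stands at a limit of the assay and not at a number: the limit of > 50000 nM in this assay, at which 1 of the 4 values shown sits. The result shows that, in these two pairs, the size of the step does not carry from one core to the other, but it does not show what sets the steps apart, and two pairs give no rule for any further core.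

From the compounds shown here alone, it remains open how an ethoxy, a hydroxyl, an amine or a carboxylic acid on the same aromatic carbon would compare with methyl and methoxy on either core. Going by these compounds, it is also open whether the step from methyl to methoxy would stay small at another carbon of the aromatic ring in compound 3.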